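This account rests on a few compounds, and the source may have more. Where it says the series, first, only, none or still open, it means among the compounds named here.

Measured in a functional assay (Pituitary gland cell) with Rattus norvegicus as the target (on this read-out higher numbers stand for an effect only at larger amounts of compound and lower numbers for an effect already at smaller amounts), so far:
compound 1, `CC(C)(N)CNC(=O)N[C@@H]1CCc2ccccc2N(Cc2ccc(-c3ccccc3-c3nn[nH]n3)cc2)C1=O`: 0.1 uM
compound 2, `CN(C(=O)CC(C)(C)N)[C@@H]1CCc2ccccc2N(Cc2ccc(-c3ccccc3-c3nn[nH]n3)cc2)C1=O`: 7 uM

Compound 1 holds the lowest number of the two. Among the compounds with values here, its only neighbour is compound 2, reached by a 70-fold higher number from compound 1 to compound 2 (1.85 log units; beyond the scatter), a change that replaces the urea link with an N-methyl amide while the terminal amine is kept.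

Compound 3, `C[C@H](O)CNC(C)(C)CNC(=O)N[C@@H]1CCc2ccccc2N(Cc2ccc(-c3ccccc3-c3nn[nH]n3)cc2)C1=O`, has not been measured. It differs from compound 1 only in 2-hydroxypropyl in place of hydrogen on an amine nitrogen. Within the data shown here, no measured step touches this amine nitrogen; the single step, a 70-fold higher number from compound 1 to compound 2 (1.85 log units; beyond the scatter), concerns the link to the ring and so gives no direct guide to alkylation of the amine. The basic nitrogen remains, and the rest of the molecule is unchanged, so the expectation is a step within the scatter, a 1.5-fold higher number from compound 1 to compound 3 (0.18 log units; within the scatter). Compound 3 is therefore estimated at 0.15 uM, with a range from 0.04 uM to 0.6 uM.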

Compound 3, concentration for half-maximal effect: 2.5 uM
Compound 3: middle estimate off by 17-fold (1.22 log units), on the low side; measured number above the stated range.
By their numbers in this assay, from the lowest: compound 1; then compound 3; then compound 2.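

In this assay the amine nitrogen proves to be a sensitive position: 2-hydroxypropyl in place of hydrogen gives a 25-fold higher number from compound 1 to compound 3 (1.40 log units; beyond the scatter) and leaves compound 1 with the lowest number of the three. The urea link stays intact in this change, so the number responds to substitution on the terminal amine as well as to the change of link seen in a 70-fold higher number from compound 1 to compound 2 (1.85 log units; beyond the scatter) on the earlier step. Nothing at hand explains the size of the new step.

From the compounds shown here alone, what stays open is whether the step follows any substituent on this nitrogen or this one in particular, which a methyl, an ethyl or a 2-hydroxyethyl group there would help to separate. A plain propyl group would isolate the contribution of the hydroxyl, and the opposite configuration at the stereocentre of the 2-hydroxypropyl group remains a further open point.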